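This account rests on a few compounds, and the source may have more. Where it says the series, first, only, none or still open, it means among the compounds named here.

Compound 1 `COc1cc(OC)c2c(=O)cc(C(=O)Nc3ccc(C4CCCCC4)cc3)[nH]c2c1`: 18400 nM in a functional assay on KOPN-8 cells (Homo sapiens) for antiproliferative activity, with a stated time of 72 h; a lower number here means that less compound is needed, a higher number that more compound is needed for the effect.
Compound 2 `COc1cc(OC)c2c(=O)cc(C(=O)Nc3ccc(N4CCN(C)CC4)cc3)[nH]c2c1`: > 19800 nM in this assay, which is a limit of the assay and not a number.

Compound 2 thus stands at the limit described in the limit of > 19800 nM in this assay, at which 1 of the 2 values shown sits, and an at least 1.0-fold higher number from compound 1 to compound 2 (0.03 log units; that floor lies within the scatter) gives only a floor. Compound 3 `COc1cc(OC)c2c(=O)cc(C(=O)Nc3ccc(Oc4ccc([N+](=O)[O-])cc4)cc3)[nH]c2c1` carries 4-nitrophenoxy in place of 4-methylpiperazin-1-yl on an aromatic carbon. Within the data shown here, no measured step swaps a group at this place for a nitrophenoxy; the only measured step concerns a different pair of groups, and both of its values sit high. Compound 3 is therefore expected to remain weak, with an at least 1.3-fold lower number from compound 2 to compound 3 (0.12 log units; that floor lies within the scatter) estimated as no step beyond the scatter. Compound 3 is expected to give 15000 nM (range 4000 nM to 30000 nM), with a fair chance that only a limit is reported.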

Compound 3, half-maximal effective concentration: 20500 nM
Estimate against measurement, compound 3: 1.4-fold (0.14 log units) below; the range from low to high includes it.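

In this assay, 4-nitrophenoxy in place of cyclohexyl on this aromatic carbon gives a 1.1-fold higher number from compound 1 to compound 3 (0.05 log units; within the scatter), so exchanging these two large groups moves the number by no more than the scatter. Compound 2 remains a limit of the assay and not a number: the limit of > 19800 nM in this assay, at which 1 of the 3 values shown sits. The step between compound 2 and compound 3 therefore cannot be read.

Going by these compounds, it remains open whether a smaller group at this place, such as an amine or a carboxylic acid, would move the number beyond the scatter. On these data alone, the effect of any change to the shared core also remains open.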